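Saturating the Acyl Chain: From Compound 1 to Compound 4

The source may report more compounds than this note shows. Statements on the series, on what has been measured and on what is new or still open speak of the compounds shown alone.

Compound 1, `CCC/C=C/C(=O)N(Cc1ccc(OC)c(O)c1)c1cc(OC)c(OC)c(OC)c1`, carries a pent-1-en-1-yl group on its carbonyl carbon and is assessed in a functional assay on HCT-116 cells (Homo sapiens) for inhibition, read by MTT assay, with a stated time of 48 h; a higher number here means a weaker inhibitor, a lower number a stronger inhibitor. In this assay compound 1 gives 95 nM, the lowest of the two numbers recorded. Compound 2, `C/C=C/C(=O)N(Cc1ccc(OC)c(N)c1)c1cc(OC)c(OC)c(OC)c1`, gives 300 nM in this assay, a higher number separated from compound 1 by a gap beyond the usual scatter. Compound 3, `COc1cc(NCc2ccccc2)cc(OC)c1OC`, reaches only a limit of this assay, > 80000 nM, and not a number (the limit of > 80000 nM in this assay, at which 1 of the 3 values shown sits).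

The unmeasured compound 4, `CCCCC(=O)N(Cc1ccc(OC)c(O)c1)c1cc(OC)c(OC)c(OC)c1`, differs from compound 1 in one place: butyl in place of pent-1-en-1-yl on a carbonyl carbon. Among the compounds with values here, no measured pair shows this change, so its size has not been observed. The step is expected to be a 2.6-fold higher number from compound 1 to compound 4 (0.42 log units; beyond the scatter), a move toward a higher number, modest and perhaps only at the edge of the scatter. Compound 4 is therefore expected to give 250 nM in this assay, within an estimated range from 70 nM to 1500 nM.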

Compound 4, half-maximal inhibitory concentration: 170 nM
Compound 4: the middle estimate sits 1.5-fold (0.17 log units) above what was measured; the measured number falls inside the stated range.
By their numbers in this assay, from the lowest: compounds 1, 4 and 2 (each within the scatter of the next, the first and the last beyond it). At a limit, above all of these: compound 3.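

Butyl in place of pent-1-en-1-yl on a carbonyl carbon gives a 1.8-fold higher number from compound 1 to compound 4 (0.25 log units; within the scatter) in this assay, the first step observed at this position. The double bond of the pent-1-en-1-yl group is therefore not needed for compound 4 to stay within the scatter of compound 1 in this assay, and this acyl chain can be saturated and shortened without a change that can be told apart from repeat measurements. Nothing among the data shown offers an explanation for this step.

The step alters chain length and the double bond together, and the compounds shown do not separate the two. On these data alone, how a longer chain, a phenyl ring or an amine on this carbonyl carbon would read in this assay remains open.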